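This account rests on a few compounds, and the source may have more. Where it says the series, first, only, none or still open, it means among the compounds named here.

Compound 1 `O=C(COc1ccc2cc(/C=C3/SC(=O)NC3=O)ccc2c1)Nc1cc(Cl)cc(C(F)(F)F)c1`, compound 2 `Cc1cccc2sc(NC(=O)COc3ccc4cc(/C=C5/SC(=O)NC5=O)ccc4c3)nc12` and compound 3 `O=C(COc1ccc2cc(/C=C3/SC(=O)NC3=O)ccc2c1)Nc1ccccc1Oc1ccccc1` share one core and differ only in the group on the amide-type nitrogen. In an assay on isolated protein for inhibition of histone deacetylase 4 (Homo sapiens), with a stated time of 1 h (on this read-out higher numbers stand for weaker inhibition and lower numbers for stronger inhibition), compound 1 gives 4000 nM, compound 2 gives 1200 nM, and compound 3 gives 5200 nM. Compound 3 thus carries the highest number of the three, but its gap to compound 1 is within the scatter, so only compound 2 is set apart, with a clearly lower number beyond the scatter.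

Compound 4 `O=C(COc1ccc2cc(/C=C3/SC(=O)NC3=O)ccc2c1)Nc1ccccc1` is reached from compound 3 by hydrogen in place of phenoxy on an aromatic carbon: the phenoxy, one six-membered aromatic ring of carbon only and one hydrogen-bond acceptor, is lost and a hydrogen takes its place.

Within the data shown here, only one measured step touches the same position, a 3.3-fold lower number from compound 1 to compound 2 (0.52 log units; beyond the scatter), and it exchanges the whole aryl group rather than removing a single substituent. That step was modest, and the smaller change from compound 1 to compound 3 stayed within the scatter, so no step beyond the scatter is expected here in this assay; if anything, a slightly higher number is expected, as compound 4 keeps the less decorated phenyl.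

Compound 4 is therefore estimated at 6000 nM, with a range from 2500 nM to 15000 nM, which corresponds to an expected step of a 1.2-fold higher number from compound 3 to compound 4 (0.06 log units; within the scatter).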

Compound 4, half-maximal inhibitory concentration: 2100 nM
The estimate for compound 4 lay 2.9-fold (0.46 log units) above the measured number, and the stated range ends above it.
By their numbers in this assay, from the lowest: compounds 2, 4, 1 and 3 (each within the scatter of the next, the first and the last beyond it).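

Among these compounds, with hydrogen in place of phenoxy, on an aromatic carbon ortho to a large group, this assay gives a 2.5-fold lower number from compound 3 to compound 4 (0.39 log units; beyond the scatter) and so shows, as the earlier compounds could not, that taking a substituent off this ring can move the number beyond the scatter. The direction is also new: the plain phenyl of compound 4 does not lose ground to the phenoxy-bearing ring of compound 3, so within this set the phenoxy brings no gain in this assay. The plain phenyl also stands close to both other groups on the amide-type nitrogen, as a 1.8-fold higher number from compound 2 to compound 4 (0.24 log units; within the scatter) and a 1.9-fold lower number from compound 1 to compound 4 (0.28 log units; within the scatter) both remain within the scatter, so compound 4 cannot be ranked against compound 1 or compound 2.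

The compounds shown leave open whether the lost ring or the linking oxygen of the phenoxy matters, which a methoxy or a benzyl group on the same carbon could begin to separate, and whether an amine or a carboxylic acid there would shift the number at all. No available evidence bears on why removing the phenoxy has this effect.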